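Compound 3: naphthalenyl on the saturated ring carbon

The source may hold more compounds than are shown below. What is called first, only, known or untested is meant among the compounds shown, and "the series" means these compounds.

Going by the values given here, in an assay on CHO cells for binding affinity to Melanocortin receptor 4 (Homo sapiens) (a higher number here means a weaker inhibitor, a lower number a stronger inhibitor), compound 1 `COc1ccc(-n2nc(Sc3ccc(Cl)cc3)cc(CC[C@@H](C)NC(=O)[C@H]3CNCC[C@@H]3c3ccccc3F)c2=O)cc1` gives 13 nM, and compound 2 `COc1ccc(-n2nc(Sc3ccc(Cl)cc3)cc(CC[C@@H](C)NC(=O)[C@H]3CNCC[C@@H]3c3ccc(C(F)(F)F)cc3)c2=O)cc1` gives 3.8 nM, the lowest of the two numbers so far; the only measured step, a 3.4-fold lower number from compound 1 to compound 2 (0.53 log units; beyond the scatter), is modest and lies beyond the scatter. Compound 3 `COc1ccc(-n2nc(Sc3ccc(Cl)cc3)cc(CC[C@@H](C)NC(=O)[C@H]3CNCC[C@@H]3c3cccc4ccccc34)c2=O)cc1` carries naphthalen-1-yl in place of 4-(trifluoromethyl)phenyl on a saturated ring carbon. That single step is the only one touching this position, and it concerns a different group, so it gives no firm direction for a second exchange of the aryl group. For compound 3 the expected value is 6 nM, within 1.5 nM to 25 nM, and the expected step of a 1.6-fold higher number from compound 2 to compound 3 (0.20 log units; within the scatter) is small, likely within the scatter.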

Compound 3, half-maximal inhibitory concentration: 89 nM
Compound 3: the middle estimate sits 15-fold (1.17 log units) below what was measured, outside the stated range (above it).
By their numbers in this assay, from the lowest: compound 2; then compound 1; then compound 3.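

In this assay the aryl group on the saturated ring carbon is not freely exchangeable: naphthalen-1-yl, with as many heavy atoms as 4-(trifluoromethyl)phenyl, gives a 23-fold higher number from compound 2 to compound 3 (1.37 log units; beyond the scatter). Against 2-fluorophenyl it gives a 6.8-fold higher number from compound 1 to compound 3 (0.84 log units; beyond the scatter), so among these three compounds both single-ring aryl groups give lower numbers than the two-ring group. Nothing available explains this loss. Open, from the compounds shown here alone, is how naphthalen-2-yl would read at this carbon, which would separate the presence of a second ring from the way it is attached. Also open, going by these compounds, is whether a phenyl ring carrying a carboxylic acid or an amine is accepted here.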